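Benzyl aryl variation on a shared core: cytotoxicity notes

The source may hold more compounds than are shown below. What is called first, only, known or untested is meant among the compounds shown, and "the series" means these compounds.

Measured compounds, read in a functional assay on QGY7701 cells (Homo sapiens) for cytotoxicity, read by MTT assay, with a stated time of 48 h; on this read-out higher numbers stand for weaker inhibition and lower numbers for stronger inhibition:
- compound 1, `O=c1ccoc2cc(OCc3cn(Cc4ccc(Cl)cc4Cl)nn3)ccc12`, gives 13300 nM.
- compound 2, `O=c1ccoc2cc(OCc3cn(Cc4ccc([N+](=O)[O-])cc4)nn3)ccc12`, gives > 100000 nM, which is a limit of the assay and not a number.
- compound 3, `O=c1ccoc2cc(OCc3cn(Cc4ccccc4Br)nn3)ccc12`, gives > 100000 nM, again a limit and not a number.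

Compound 1 holds the only number shown; the other two values are limits, as the limit of > 100000 nM in this assay, at which 2 of the 3 values shown sit, records. Both measured steps leave compound 1: an at least 7.5-fold higher number from compound 1 to compound 2 (0.87 log units; beyond the scatter), and an at least 7.5-fold higher number from compound 1 to compound 3 (0.87 log units; beyond the scatter). The step between compound 2 and compound 3 is a step that the two limits leave unreadable from compound 2 to compound 3.

Compound 4, `N#Cc1cccc(Cn2cc(COc3ccc4c(=O)ccoc4c3)nn2)c1`, is still to be measured. Its difference from compound 1 is 3-cyanophenyl in place of 2,4-dichlorophenyl on a saturated chain carbon bound to an aromatic nitrogen. Within the data shown here, both steps that bear on it, the one to compound 2 and the one to compound 3, are each a change of the aryl on the saturated chain carbon bound to an aromatic nitrogen, and each raised the number beyond the scatter, to a limit. A higher number is therefore expected for compound 4 as well, with a fair chance that this assay reports only a limit. The estimate for compound 4 is 60000 nM, with a range from 15000 nM to 200000 nM. That estimate corresponds to an expected step of a 4.5-fold higher number from compound 1 to compound 4 (0.65 log units; beyond the scatter).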

Compound 4, half-maximal inhibitory concentration: 24400 nM
Beside the measured number, compound 4's estimate is 2.5-fold (0.39 log units) above it; the range from low to high includes it.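

In this assay, among these compounds, 3-cyanophenyl is the first replacement for 2,4-dichlorophenyl on the saturated chain carbon bound to an aromatic nitrogen that stays within the scatter (a 1.8-fold higher number from compound 1 to compound 4 (0.26 log units; within the scatter)), so this position does not lose its readable number with every change of aryl, and compound 4 goes against the rise to a limit seen for compound 2 and compound 3. The same aryl change also separates compound 4 from the two inactive-looking members of the set, with steps beyond the scatter on both sides (an at least 4.0-fold lower number from compound 3 to compound 4 (0.61 log units; beyond the scatter); an at least 4.0-fold lower number from compound 2 to compound 4 (0.61 log units; beyond the scatter)), so the choice of aryl matters here even without chlorine on the ring. Compound 2 and compound 3 remain limits and not numbers, and the series still has this ceiling: the limit of > 100000 nM in this assay, at which 2 of the 4 values shown sit.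

Among the compounds shown here, the step between compound 2 and compound 3 cannot be read, so the order of 4-nitrophenyl and 2-bromophenyl stays unknown, and with only two numbers in the set no trend across the aryl groups can be drawn. On these data alone, how an amine or a carboxylic acid on the aryl would read, or a longer chain in place of the saturated chain carbon, stays open.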